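Phenyl in Place of Methyl on a Ring Nitrogen

The compounds below may be only part of what the source reports. "The series", "measured", "known", "first", "only" and "open" are said of these compounds alone.

Three compounds share one core and were tested in a functional assay on A-375 cells (Homo sapiens) for antiproliferative activity, read by trypan blue exclusion, with a stated time of 48 h, tested at 1 uM; on this read-out higher numbers stand for a weaker effect at the one concentration tested and lower numbers for a stronger effect. Compound 1 `CCCCCCC#Cc1ccc(S(=O)(=O)Nc2cccc(-c3csc(NC(C)=O)n3)c2)cc1` gives 40.7%. Compound 2 `CCCCCCCCC#Cc1ccc(S(=O)(=O)Nc2cccc(-c3csc(NC(C)=O)n3)c2)cc1` gives 39.6%, and the change of ethyl in place of hydrogen on a saturated chain carbon brings a number 1.1 percentage points lower from compound 1 to compound 2 (within the scatter). Compound 3 `CCCCCCC#Cc1ccc(S(=O)(=O)Nc2cccc(-c3csc(NC)n3)c2)cc1` gives 36.6%, reached through methyl in place of acetyl on a nitrogen on an aromatic ring, a step of a number 4.1 percentage points lower from compound 1 to compound 3 (within the scatter). On these numbers compound 3 sits close to both compound 1 and compound 2, within the scatter of each, so no ordering among the three can be read.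

Compound 4 `CCCCCCC#Cc1ccc(S(=O)(=O)Nc2cccc(-c3csc(Nc4ccccc4)n3)c2)cc1` differs from compound 3 by phenyl in place of methyl on a nitrogen on an aromatic ring. Among the compounds with values here, only the step from compound 1 to compound 3 touches this same nitrogen, and it stayed within the scatter; the step from compound 1 to compound 2 lies elsewhere and was also within the scatter. Within the data shown here, no measured pair shows a phenyl entering at this place, so the expectation rests on the quiet behaviour of this position so far. Compound 4 is therefore estimated at 34% in this assay, with a range from 14% to 58%. The step this estimate implies is a number 2.6 percentage points lower from compound 3 to compound 4 (within the scatter), expected to remain within the scatter.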

Compound 4, a percentage reported as activity, at one concentration (the size of the read-out at that concentration, not a potency): 87.1%
The estimate for compound 4 lay 53.1 percentage points below the measured number; the measured number lies above the stated range.
By their numbers in this assay, from the lowest: compounds 3, 2 and 1 (each within the scatter of the next); then compound 4.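

In this assay, the nitrogen on the aromatic ring proved far from indifferent to what it carries: phenyl in place of methyl gives a number 50.5 percentage points higher from compound 3 to compound 4 (beyond the scatter), and phenyl in place of acetyl gives a number 46.4 percentage points higher from compound 1 to compound 4 (beyond the scatter), both large steps toward a weaker effect at the one concentration tested. Methyl and acetyl had stayed within the scatter of each other at this nitrogen, so the quiet seen earlier holds for those two groups only, and phenyl, with its six-membered aromatic ring of carbon only, is the first group shown here to shift the read-out at this place. Nothing available explains the size of this loss.

The compounds shown leave open whether the loss follows from the aromatic ring itself or from the larger group more generally, since a cyclohexyl ring or a butyl chain on this nitrogen would separate the two. They also leave open how an unsubstituted amine at this place would read, and whether phenyl has the same effect when the core carries the longer chain of compound 2.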